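Methoxy count on the cinnamoyl aryl in a macrocyclic series

A few compounds are considered here, and "the series" means these few. Any claim that something is new, unique, unknown or untested is made for them only; others in the source may bear on it.

Three members of the series carry the same macrocyclic lactam core linked through an ether tether to a chalcone-type aryl ketone. Compound 1 `C/C1=C\CC(C)(C)/C=C/C(=O)N(Cc2cn(CCOc3ccc(C(=O)/C=C/c4ccc(C)cc4)c(O)c3)nn2)/C(C)=C/CC1` and compound 2 `C/C1=C\CC(C)(C)/C=C/C(=O)N(Cc2cn(CCOc3ccc(C(=O)/C=C/c4ccc(C(C)C)cc4)c(O)c3)nn2)/C(C)=C/CC1` share a triazole-containing tether; in a functional assay on MCF7 cells (Homo sapiens) for antiproliferative activity (a lower number here means a stronger inhibitor, a higher number a weaker inhibitor), compound 1 gives 1.21 ug/mL and compound 2 gives 0.93 ug/mL. For the measured compounds named here, the one measured step, a 1.3-fold lower number from compound 1 to compound 2 (0.11 log units; within the scatter), is the exchange of isopropyl for methyl on the aromatic carbon and falls within the scatter. Compound 3 `COc1cccc(/C=C/C(=O)c2ccc(OCCCN3C(=O)/C=C/C(C)(C)C/C=C(\C)CC/C=C/3C)cc2)c1` has a plain propyl tether and a meta-methoxy aryl; in this assay compound 3 gives 1.37 ug/mL, the upper end of the three numbers, though its gap to compound 1 and its gap to compound 2 both lie within the scatter.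

Compound 4 `COc1cc(/C=C/C(=O)c2ccc(OCCCN3C(=O)/C=C/C(C)(C)C/C=C(\C)CC/C=C/3C)cc2)cc(OC)c1OC` differs from compound 3 only in the aryl: 3,4,5-trimethoxyphenyl in place of 3-methoxyphenyl on a double-bonded chain carbon bound to a double-bonded chain carbon. Going by the values given here, no measured step touches a change of this kind; the single step available, from compound 1 to compound 2, concerns a different substituent on the same kind of ring and itself stayed within the scatter. The expectation is therefore a step no larger than the scatter, with no direction to assign, so that a 1.1-fold lower number from compound 3 to compound 4 (0.06 log units; within the scatter) is the estimated change. Compound 4 is estimated at 1.2 ug/mL, with a range from 0.5 ug/mL to 3 ug/mL.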

Compound 4, half-maximal inhibitory concentration: 0.58 ug/mL
The estimate for compound 4 lay 2.1-fold (0.32 log units) above the measured number; low and high end bracket the measured number.
By their numbers in this assay, from the lowest: compounds 4, 2, 1 and 3 (each within the scatter of the next, the first and the last beyond it).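

In this assay, for the compounds shown here, 3,4,5-trimethoxyphenyl in place of 3-methoxyphenyl on a double-bonded chain carbon bound to a double-bonded chain carbon gives a 2.4-fold lower number from compound 3 to compound 4 (0.37 log units; beyond the scatter) and is the first step to pass beyond the scatter; the only earlier step, a 1.3-fold lower number from compound 1 to compound 2 (0.11 log units; within the scatter) for isopropyl in place of methyl on an aromatic carbon, stayed within it. This aryl group is therefore not a silent part of the structure, at least on the propyl tether, although the step is modest and rests on a single pair, so it marks a difference between two compounds and not a trend with methoxy count. No evidence on hand bears on what lies behind the step.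

Which of the added methoxy groups matters stays open, and 4-methoxyphenyl or 3,5-dimethoxyphenyl on the same tether would separate them, while an ethoxy group or an amine on this aryl would test whether methoxy itself is needed. Whether 3,4,5-trimethoxyphenyl gives a similar step on the triazole-containing tether of compound 1 also remains unanswered.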